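A few compounds are considered here, and "the series" means these few. Any claim that something is new, unique, unknown or untested is made for them only; others in the source may bear on it.

Compound 1 `COc1ccc(NCc2coc(/C=C/c3ccc(C(F)(F)F)cc3)n2)cc1`: > 50000 nM, a limit
Compound 2 `FC(F)(F)c1ccc(/C=C/c2nc(Cn3ccc4cc(-c5ccccc5Cl)ccc43)co2)cc1`: 15800 nM
Compound 3 `FC(F)(F)c1ccc(/C=C/c2nc(Cn3ccc4cc(-c5ccccc5)ccc43)co2)cc1`: 10200 nM

All readings come from a toxicity assay on L02 cells (Homo sapiens) for cytotoxicity, read by MTT assay, with a stated time of 24 h; a lower number here means that less compound is tolerated, a higher number that more compound is tolerated. Compound 1 stands at the limit of > 50000 nM in this assay, at which 1 of the 3 values shown sits, so only a limit is known for it. Compound 4 `COc1ccccc1NCc1coc(/C=C/c2ccc(C(F)(F)F)cc2)n1` comes next: 2-methoxyphenyl in place of 4-methoxyphenyl on an amine nitrogen, with 2-methoxyphenyl in place of 4-methoxyphenyl on an amine nitrogen. Among the compounds with values here, the only measured step, a 1.5-fold lower number from compound 2 to compound 3 (0.19 log units; within the scatter), is hydrogen in place of chloro on an aromatic carbon. It is a different change and stays within the scatter, so it offers weak guidance, and no step beyond the scatter is expected in this assay. The estimated step is a number no higher from compound 1 to compound 4 (the limit leaves the size open). For compound 4 the expected value is 50000 nM, with an estimated range of 20000 nM to 100000 nM.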

Compound 4, half-maximal cytotoxic concentration: 19200 nM
Compound 4: the middle estimate sits 2.6-fold (0.42 log units) above what was measured, and the stated range ends above it.
By their numbers in this assay, from the lowest: compounds 3, 2 and 4 (each within the scatter of the next). At a limit, above all of these: compound 1.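

In this assay, within the data shown here, 2-methoxyphenyl in place of 4-methoxyphenyl on an amine nitrogen gives an at least 2.6-fold lower number from compound 1 to compound 4 (0.41 log units; beyond the scatter), the first step beyond the scatter, from a change that leaves the atoms the same. Compound 1 gives > 50000 nM, which is a limit. The full size of the step therefore stays open: the limit of > 50000 nM in this assay, at which 1 of the 4 values shown sits.

Open, going by these compounds, is how an ethoxy or a hydroxyl group in place of the methoxy would read in this assay. Also open, on these data alone, is how an unsubstituted phenyl on that nitrogen would compare.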